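Removing a side group from compound 2

This account rests on a few compounds, and the source may have more. Where it says the series, first, only, none or still open, it means among the compounds named here.

- Compound 1 `Nc1ccccc1NC(=O)c1ccc(CNc2nc3cc(Cl)ccc3o2)cc1` gives 200 nM
- Compound 2 `Nc1ccccc1NC(=O)c1ccc(CSc2nc3ccc(NCc4cccnc4)cc3s2)cc1` gives 1000 nM
- Compound 3 `Nc1ccccc1NC(=O)c1ccc(CSc2nnc(-c3ccccc3)o2)cc1` gives 400 nM

These three compounds were measured in a functional assay on HCT-116 cells (Homo sapiens) for cytotoxicity, read by MTT assay; a lower number here means a stronger inhibitor, a higher number a weaker inhibitor. Compound 2 has the highest number of the three, which makes it the weakest inhibitor of the group, and its gaps to compound 3 and compound 1 both lie beyond the usual scatter.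

The next compound, compound 4 `Nc1ccccc1NC(=O)c1ccc(CSc2nc3ccccc3s2)cc1`, is a simpler version of compound 2: hydrogen in place of ((pyridin-3-yl)methyl)amino on an aromatic carbon. Hydrogen takes the place of ((pyridin-3-yl)methyl)amino on an aromatic carbon.

Within the data shown here, no two measured compounds differ in only one place, so no direct step can guide the expectation. The only clue is indirect, since neither compound 3 nor compound 1 carries that group. Compound 3 gives 400 nM, and compound 1 gives 200 nM. A modest drop in the number, meaning a stronger inhibitor, is therefore expected, though this is uncertain.

The estimated size is a 2.2-fold lower number from compound 2 to compound 4 (0.35 log units; beyond the scatter).

For compound 4 the expected value is 450 nM, with an estimated range of 150 nM to 1300 nM.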

Compound 4, half-maximal inhibitory concentration: 800 nM
Compound 4: the middle estimate sits 1.8-fold (0.25 log units) below what was measured; the range from low to high includes it.
By their numbers in this assay, from the lowest: compounds 1, 3, 4 and 2 (each within the scatter of the next, the first and the last beyond it).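

In this assay replacing ((pyridin-3-yl)methyl)amino with hydrogen on this aromatic carbon gives a 1.3-fold lower number from compound 2 to compound 4 (0.10 log units; within the scatter) and so leaves the two compounds indistinguishable. Among these compounds, removing this large side group therefore brings no clear gain or loss in this cell read-out, which the earlier compounds could not show because no two of them differed in only one place. No supporting measurement is available to explain why the side group makes so little difference here.

This single pair cannot show whether a different group at this position, such as a plain amine or a carboxylic acid, would separate from hydrogen. It also leaves open whether a longer chain between the aromatic carbon and the same ring would give a result any different from compound 2.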